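Side-chain exchange on the shared core: compound 3 to compound 4

This account rests on a few compounds, and the source may have more. Where it says the series, first, only, none or still open, it means among the compounds named here.

Three compounds share one core and differ only in the group on a saturated chain carbon bound to a saturated ring carbon. In an ADME assay on Vero cells (Chlorocebus sabaeus) for cytotoxicity, with a stated time of 7 days (a higher number here means that more compound is tolerated, a lower number that less compound is tolerated), compound 1 `COc1ccc2[nH]c(C(=O)N3CC(=O)N(Cc4ccccc4)[C@@H](COc4ccccc4)C3)cc2c1` gives a value that is a limit of the assay, > 10000 nM. Compound 2 `COc1ccc2[nH]c(C(=O)N3CC(=O)N(Cc4ccccc4)[C@@H](CN4CCC5(CC4)CC5)C3)cc2c1` gives 17100 nM in this assay. Compound 3 `COc1ccc2[nH]c(C(=O)N3CC(=O)N(Cc4ccccc4)[C@@H](CN4C(=O)c5ccccc5C4=O)C3)cc2c1` gives 41000 nM in this assay, the higher of the two readable numbers. The step of a 2.4-fold higher number from compound 2 to compound 3 (0.38 log units; beyond the scatter) is the only one of readable size; the steps a step that the limit leaves unreadable from compound 1 to compound 2 and a step that the limit leaves unreadable from compound 1 to compound 3 begin at the limit of > 10000 nM in this assay, at which 1 of the 3 values shown sits, and cannot be sized.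

Compound 4 `COc1ccc2[nH]c(C(=O)N3CC(=O)N(Cc4ccccc4)[C@@H](CN4CCn5cccc5C4)C3)cc2c1` is the next member: a group of 9 heavy atoms (7 carbon, 2 nitrogen; one five-membered aromatic ring with 1 hetero atom, one six-membered non-aromatic ring with 2 hetero atoms) in place of a group of 11 heavy atoms (8 carbon, 1 nitrogen, 2 oxygen; one five-membered non-aromatic ring with 1 hetero atom, one six-membered aromatic ring of carbon only), on a saturated chain carbon bound to a saturated ring carbon. Among the compounds with values here, no measured step shows this exact exchange. The nearest comparison is a 2.4-fold higher number from compound 2 to compound 3 (0.38 log units; beyond the scatter), in which the entering group also replaced a six-membered non-aromatic ring with 1 hetero atom, and the lower number there belonged to compound 2 with 17100 nM. Compound 4 again carries a six-membered non-aromatic ring with 2 hetero atoms at this position, so a modest move back toward compound 2 is expected, a 1.6-fold lower number from compound 3 to compound 4 (0.21 log units; within the scatter), possibly within the scatter. Compound 4 is therefore estimated at 25000 nM, with a range from 10000 nM to 60000 nM.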

Compound 4, half-maximal cytotoxic concentration: > 100000 nM
Compound 4 ended at the assay's limit (the forecaster's own chance of this, stated with the estimate: 15%); middle value at least 4.0-fold (0.60 log units) away from the limit.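

Within the data shown here, at this position, on a saturated chain carbon bound to a saturated ring carbon, the side chain can now be seen to move the tolerated concentration in this assay by more than the single modest step between compound 2 and compound 3 showed: the group with one five-membered aromatic ring and one six-membered non-aromatic ring with 2 hetero atoms gives an at least 2.4-fold higher number from compound 3 to compound 4 (0.38 log units; beyond the scatter) and an at least 5.8-fold higher number from compound 2 to compound 4 (0.76 log units; beyond the scatter). Both steps are minimum sizes, as the result for compound 4 is a limit of the assay and not a number: the limit of > 100000 nM in this assay, at which 1 of the 4 values shown sits. The steps from compound 1, itself at a limit, to compound 2, compound 3 and compound 4 cannot be read, so the phenoxy-bearing compound 1 cannot be placed against this group.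

Still open, on these data alone, is which part of the entering group goes with the higher number, the five-membered aromatic ring or the six-membered non-aromatic ring with 2 hetero atoms. A piperazine or a lone pyrrole on the same saturated chain carbon would separate the two, and a carboxylic acid there would test the position with a different kind of group.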